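The source may hold more compounds than are shown below. What is called first, only, known or untested is meant among the compounds shown, and "the series" means these compounds.

In a functional assay on MCF7 cells (Homo sapiens) for antiproliferative activity, read by CellTiter-Glo, with a stated time of 5 days (on this read-out lower numbers stand for stronger inhibition and higher numbers for weaker inhibition), three compounds have been measured:
compound 1 `CC1=C(c2cccc(O)c2)C(c2ccc(OC[C@H](C)N3CC[C@@H](C)C3)cc2)Oc2cc(O)ccc21` gives 0.3 nM in this test
compound 2 `CC1=C(c2cccc(O)c2)C(c2ccc(OC[C@H](C)N3CCCCCC3)cc2)Oc2ccc(O)cc21` gives 0.2 nM in this test
compound 3 `CC1=C(c2ccc(O)cc2)C(c2ccc(OC[C@H](C)N3CC[C@@H](C)C3)cc2)Oc2ccc(O)cc21` gives 0.1 nM in this test

Compound 1 stands within the scatter of compound 2, while compound 3 has a lower number than compound 1 by more than the scatter. The compound still to be measured is compound 4 `CC1=C(c2ccc(O)cc2)C(c2ccc(OC[C@H](C)N3CC[C@@H](C)C3)cc2)Oc2cc(O)ccc21`, which keeps the shared core and side chain of compound 1 and alters one group: 4-hydroxyphenyl in place of 3-hydroxyphenyl on a double-bonded ring carbon is the whole change. Among the compounds with values here, no measured pair shows this change alone. Compound 3 carries the 4-hydroxyphenyl and gives 0.1 nM in this assay, but it also differs from compound 1 elsewhere on the core, so it offers only a loose guide. On that evidence, a small move towards a lower number is expected, probably not beyond the scatter. The expected change is a 1.5-fold lower number from compound 1 to compound 4 (0.18 log units; within the scatter) as estimated here. For compound 4 the estimated value is 0.2 nM, with an expected range from 0.07 nM to 0.6 nM in this estimate.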

Compound 4, half-maximal inhibitory concentration: 0.2 nM
Compound 4: middle estimate and measured number agree at the digits printed; the range from low to high includes it.
By their numbers in this assay, from the lowest: compounds 3, 2, 4 and 1 (each within the scatter of the next, the first and the last beyond it).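

In this assay the exchange of 3-hydroxyphenyl for 4-hydroxyphenyl on the double-bonded ring carbon can now be read alone, and the result is a 1.5-fold lower number from compound 1 to compound 4 (0.18 log units; within the scatter), a step that does not separate the two groups. Within the data shown here, on the shared core and side chain of compound 1, this position therefore tolerates either hydroxyphenyl group without a change that this read-out can resolve, something the earlier compounds could not show, since compound 2 and compound 3 each differ from compound 1 in more than one place. No measurement available here bears on the reason for this outcome.

The compounds shown leave open whether the hydroxyl on this ring matters at all, a question that an unsubstituted phenyl, a methoxyphenyl or a fluorophenyl at the same place would address, and how 2-hydroxyphenyl would compare. They also leave open whether the same tolerance holds with the different side chain of compound 2, where only the 3-hydroxyphenyl form appears, and in any test other than this cell read-out.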